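Dimethylamino to triazole: compound 3 to compound 4

The source may report more compounds than this note shows. Statements on the series, on what has been measured and on what is new or still open speak of the compounds shown alone.

In a functional assay on HUVEC cells (Homo sapiens), read by scintillation counting and thymidine incorporation, with a stated time of 24 h (a higher number here means a weaker inhibitor, a lower number a stronger inhibitor), compound 1 (`CCC(C)n1ncn(-c2ccc(N3CCN(c4ccc(OC[C@@H]5COC(c6ccc(Cl)cc6Cl)O5)cc4)CC3)cc2)c1=O`) gives 328 nM and compound 2 (`CCC(C)n1ncn(-c2ccc(N3CCN(c4ccc(OC[C@@H]5CO[C@@](CC)(c6ccc(Cl)cc6Cl)O5)cc4)CC3)cc2)c1=O`) gives 353 nM, two values close together. Compound 3 (`CCC(C)n1ncn(-c2ccc(N3CCN(c4ccc(OC[C@@H]5CO[C@@](CN(C)C)(c6ccc(Cl)cc6Cl)O5)cc4)CC3)cc2)c1=O`) has the highest number of the three at 1400 nM. Compound 4 (`CCC(C)n1ncn(-c2ccc(N3CCN(c4ccc(OC[C@@H]5CO[C@@](Cn6cnc(C(F)(F)F)n6)(c6ccc(Cl)cc6Cl)O5)cc4)CC3)cc2)c1=O`) puts 3-(trifluoromethyl)-1H-1,2,4-triazol-1-yl in place of dimethylamino on a saturated chain carbon bound to a saturated ring carbon. Among the measured compounds shown here, the one measured step at this place is a 4.0-fold higher number from compound 2 to compound 3 (0.60 log units; beyond the scatter), which is beyond the scatter. For the measured compounds named here, no measured compound carries a triazolyl group, so the evidence is thin. A partial return toward the level of compound 2 at 353 nM is expected, giving a lower number. In this assay the expected change is a 3.5-fold lower number from compound 3 to compound 4 (0.54 log units; beyond the scatter). Compound 4 is estimated at 400 nM, with a range of 150 nM to 1100 nM.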

Compound 4, half-maximal inhibitory concentration: 270 nM
Beside the measured number, compound 4's estimate is 1.5-fold (0.17 log units) above it, and the stated range covers the measured number.
By their numbers in this assay, from the lowest: compounds 4, 1 and 2 (each within the scatter of the next); then compound 3.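

In this assay the loss seen with dimethylamino does not extend to every group at this place: a 5.2-fold lower number from compound 3 to compound 4 (0.71 log units; beyond the scatter) is beyond the scatter, while a 1.3-fold lower number from compound 2 to compound 4 (0.12 log units; within the scatter) is within it. On a saturated chain carbon bound to a saturated ring carbon, 3-(trifluoromethyl)-1H-1,2,4-triazol-1-yl therefore reads the same as the methyl of the ethyl chain in compound 2. Nothing measured here accounts for the gap between the two groups. Open, from the compounds shown here alone, is where a primary amine, a carboxylic acid or an unsubstituted 1,2,4-triazole would fall at this place, and so what the trifluoromethyl itself contributes.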